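Swapping Chloro for Methyl on the Oxazole Core

This account rests on a few compounds, and the source may have more. Where it says the series, first, only, none or still open, it means among the compounds named here.

Measured compounds:
compound 1 `CC(=O)c1coc(C(=O)CCCCCCc2ccccc2)n1`: 123 nM
compound 2 `CS(=O)(=O)c1coc(C(=O)CCCCCCc2ccccc2)n1`: 389 nM
compound 3 `O=C(CCCCCCc1ccccc1)c1nc(Cl)co1`: 2400 nM

The three measured compounds share one core and differ only in the group on one aromatic carbon of the five-membered ring. In an assay on HEK-293T cells for inhibition of diacylglycerol lipase-alpha (Homo sapiens), read by colorimetric assay (on this read-out higher numbers stand for weaker inhibition and lower numbers for stronger inhibition), compound 3 stands at the high end of the three numbers, meaning it is the weakest inhibitor of the set: the step of a 20-fold higher number from compound 1 to compound 3 (1.29 log units; beyond the scatter) is large, and the step of a 6.2-fold higher number from compound 2 to compound 3 (0.79 log units; beyond the scatter) is modest, both beyond the scatter. The step of a 3.2-fold higher number from compound 1 to compound 2 (0.50 log units; beyond the scatter) is modest as well.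

Compound 4 `Cc1coc(C(=O)CCCCCCc2ccccc2)n1` is not yet measured. It differs from compound 3 in one place: methyl in place of chloro on an aromatic carbon.

For the measured compounds named here, no measured step covers this exact change. The two steps that end at compound 3 show that taking away acetyl or methylsulfonyl in favour of chloro costs potency, but neither tells how methyl compares with chloro; both groups are single heavy atoms without donors or acceptors. The expectation for compound 4 in this assay is therefore a step of uncertain direction, a 1.3-fold higher number from compound 3 to compound 4 (0.10 log units; within the scatter), likely within the scatter. The estimated value for compound 4 is 3000 nM, with a range from 1000 nM to 9000 nM.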

Compound 4, half-maximal inhibitory concentration: > 10000 nM
Compound 4 ended at the assay's limit (the forecaster's own chance of this, stated with the estimate: 10%); middle value at least 3.3-fold (0.52 log units) away from the limit.
By their numbers in this assay, from the lowest: compound 1; then compound 2; then compound 3. At a limit, above all of these: compound 4.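

In this assay compound 4 gives > 10000 nM, which is a limit of the assay and not a number: the limit of > 10000 nM in this assay, at which 1 of the 4 values shown sits. Even so, the step can be read as a minimum, and an at least 4.1-fold higher number from compound 3 to compound 4 (0.61 log units; beyond the scatter) shows that chloro and methyl are not interchangeable on this aromatic carbon next to the ring nitrogen, although the two groups match in their counts of heavy atoms, hydrogen-bond donors and hydrogen-bond acceptors. The wider steps, an at least 25-fold higher number from compound 2 to compound 4 (1.41 log units; beyond the scatter) and an at least 81-fold higher number from compound 1 to compound 4 (1.91 log units; beyond the scatter), extend the order seen so far, so that among these four groups acetyl gives the strongest inhibition, followed by methylsulfonyl, then chloro, with methyl last, and matching counts of this kind are not enough to predict potency here.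

From the compounds shown here alone, the true size of all three new steps stays open, as each one gives only a minimum set by the limit. The compounds shown also leave open where a bromo group, a nitrile, a methyl ester or an amide on this same carbon would fall in that order, and whether any of them would match or exceed acetyl.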